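Exchanging the aryl group on a shared guanidine scaffold

The source may report more compounds than this note shows. Statements on the series, on what has been measured and on what is new or still open speak of the compounds shown alone.

Compound 1 `Cc1nc(N)sc1CCCN/C(N)=N/C(=O)NC(C)c1ccc(Br)cc1` gives 30.2 nM in an assay on membranes from Sf9 cells for displacement of a labelled ligand from histamine H2 receptor (Homo sapiens), read by scintillation counting, with a stated time of 60 min; a lower number here means a stronger inhibitor, a higher number a weaker inhibitor.
Compound 2 `Cc1ccc(C(C)NC(=O)/N=C(\N)NCCCc2sc(N)nc2C)cc1` gives 30.9 nM.
Compound 3 `Cc1nc(N)sc1CCCN/C(N)=N/C(=O)NC(C)c1ccco1` gives 31.6 nM.

Compound 3 cannot be told apart from its two neighbours: a 1.0-fold higher number from compound 1 to compound 3 (0.02 log units; within the scatter) and a 1.0-fold higher number from compound 2 to compound 3 (0.01 log units; within the scatter), so all three numbers sit together. Compound 4 `Cc1nc(N)sc1CCCN/C(N)=N/C(=O)NC(C)c1cccc(F)c1` differs from compound 3 in one place: 3-fluorophenyl in place of furan-2-yl on a saturated chain carbon bound to an amide-type nitrogen and a saturated chain carbon. The steps already measured all exchanged the group on this same carbon, and each left this assay unchanged beyond the scatter: a 1.0-fold higher number from compound 1 to compound 2 (0.01 log units; within the scatter) and a 1.0-fold higher number from compound 2 to compound 3 (0.01 log units; within the scatter). A bromophenyl, a methylphenyl and a furan gave the same result, so a fluorophenyl is expected to do likewise. The expected step is therefore a 1.1-fold lower number from compound 3 to compound 4 (0.02 log units; within the scatter). Compound 4 is estimated to give 30 nM, with a range from 15 nM to 60 nM.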

Compound 4, inhibition constant: 2.04 nM
For compound 4 the middle estimate is 15-fold (1.17 log units) above the measured one; measured number below the stated range.
By their numbers in this assay, from the lowest: compound 4; then compounds 1, 2 and 3 (each within the scatter of the next).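

This position is not indifferent to the group it carries. In this assay the 3-fluorophenyl stands clearly apart from the furan-2-yl (a 15-fold lower number from compound 3 to compound 4 (1.19 log units; beyond the scatter)), the 4-methylphenyl (a 15-fold lower number from compound 2 to compound 4 (1.18 log units; beyond the scatter)) and the 4-bromophenyl (a 15-fold lower number from compound 1 to compound 4 (1.17 log units; beyond the scatter)), although those three gave numbers within the scatter of one another. No measurement available here explains this large step. As far as these compounds go, what a plain phenyl or a 3-chlorophenyl would give on this carbon stays open, so whether the fluorine itself matters remains unclear.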